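From 4-methoxyphenyl to 4-bromophenyl in an antiproliferative series

The source may report more compounds than this note shows. Statements on the series, on what has been measured and on what is new or still open speak of the compounds shown alone.

In a functional assay on MCF7 cells (Homo sapiens) for antiproliferative activity, read by MTT assay, with a stated time of 72 h (a lower number here means a stronger inhibitor, a higher number a weaker inhibitor), compound 1 (`COc1ccc(NC(=S)Nc2nc(C(=O)NCc3ccccc3)cs2)cc1`) gives 24600 nM and compound 2 (`CCOC(=O)c1csc2nc(CN3CCN(C)CC3)c(-c3ccc(OC)cc3)n12`) gives 32800 nM while compound 3 (`CCOC(=O)c1csc2nc(CN3CCN(Cc4ccccc4)CC3)c(-c3ccc(OC)cc3)n12`) gives 17100 nM as its reading. These three values lie within the scatter of each other, so compound 3 cannot be separated from either of the other two on these numbers.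

Compound 4 (`CCOC(=O)c1csc2nc(CN3CCN(Cc4ccccc4)CC3)c(-c3ccc(Br)cc3)n12`) has not yet been measured. Compared with compound 3, it carries bromo in place of methoxy on an aromatic carbon, the change from 4-methoxyphenyl to 4-bromophenyl, on a six-membered aromatic ring of carbon only and para to a large group (bromo in place of methoxy on an aromatic carbon). Among the measured compounds shown here, the only measured step between compounds that differ in one place is a 1.9-fold lower number from compound 2 to compound 3 (0.28 log units; within the scatter) (phenyl in place of hydrogen on a saturated chain carbon bound to an amine nitrogen in a ring) and it concerns a different part of the molecule. For the measured compounds named here, no measured compound carries bromo, so the data offer no direct guide to this change. Resting on the small size of a 1.9-fold lower number from compound 2 to compound 3 (0.28 log units; within the scatter) alone, no step beyond the scatter is expected in this assay for this change. The expected step is a 1.1-fold lower number from compound 3 to compound 4 (0.03 log units; within the scatter) on this reasoning. Compound 4 is expected at 16000 nM with an estimated range from 6500 nM to 38000 nM as its plausible span.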

Compound 4, half-maximal inhibitory concentration: 51400 nM
Compound 4: the middle estimate sits 3.2-fold (0.51 log units) below what was measured, and the stated range ends below it.
By their numbers in this assay, from the lowest: compounds 3, 1, 2 and 4 (each within the scatter of the next, the first and the last beyond it).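

At this position, on a six-membered aromatic ring of carbon only and para to a large group, the change of bromo in place of methoxy gives a 3.0-fold higher number from compound 3 to compound 4 (0.48 log units; beyond the scatter) in this assay. This is the first step shown to lie beyond the scatter, whereas the only earlier step, a 1.9-fold lower number from compound 2 to compound 3 (0.28 log units; within the scatter), stayed within it and concerned a different part of the molecule. The position is therefore not indifferent in this assay, and of the two groups compared here methoxy goes with the lower number, although this rests on a single pair of compounds and no measured property bears on the step.

The compounds shown leave open whether the rise follows from the loss of methoxy or from the arrival of bromo, as only these two groups appear at this position, and a plain hydrogen, a chloro group or an amine there would help to separate the two readings. They also leave open whether the same change would give a step of similar size on the methyl-bearing background of compound 2.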